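A few compounds are considered here, and "the series" means these few. Any claim that something is new, unique, unknown or untested is made for them only; others in the source may bear on it.

Values in a functional assay on KB 3-1 cells (Homo sapiens) for cytotoxicity, read by MTT assay, with a stated time of 72 h; a lower number here means a stronger inhibitor, a higher number a weaker inhibitor:
- compound 1 `O=C1Nc2ccccc2/C1=N/NC(=S)NCc1ccccc1`: 11700 nM
- compound 2 `CNC(=S)N/N=C1\C(=O)Nc2ccccc21`: 35300 nM
- compound 3 `O=C1Nc2ccccc2/C1=N/NC(=S)Nc1cccc(Cl)c1`: 1870 nM

Compound 3, at 1870 nM, has the lowest number of the three and is the strongest inhibitor so far in this assay. Next in the series is compound 4 `O=C1Nc2ccccc2/C1=N/NC(=S)Nc1ccc(F)cc1`, not yet measured, which carries 4-fluorophenyl in place of 3-chlorophenyl on an amide-type nitrogen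

Two measured steps change the group on this nitrogen: a 6.3-fold lower number from compound 1 to compound 3 (0.80 log units; beyond the scatter) and a 19-fold lower number from compound 2 to compound 3 (1.28 log units; beyond the scatter). Both end on 3-chlorophenyl, but they start from benzyl and methyl. Neither compares one substituted phenyl with another, so the size of this swap has not been measured directly. The phenyl ring stays on the nitrogen, so a change much smaller than the step from compound 2 is expected, and only a modest rise is anticipated, with weak support for that direction. The expected change is a 1.9-fold higher number from compound 3 to compound 4 (0.27 log units; within the scatter). For compound 4 the estimate is 3500 nM, with an expected range from 1200 nM to 10000 nM.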

Compound 4, half-maximal inhibitory concentration: 14200 nM
For compound 4 the middle estimate is 4.1-fold (0.61 log units) below the measured one, and the stated range ends below it.
By their numbers in this assay, from the lowest: compound 3; then compounds 1 and 4 (each within the scatter of the next); then compound 2.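

In this assay, keeping a substituted phenyl ring on the amide-type nitrogen does not by itself preserve the number, since replacing 3-chlorophenyl with 4-fluorophenyl gives a 7.6-fold higher number from compound 3 to compound 4 (0.88 log units; beyond the scatter) and shows that this position separates one substituted phenyl from another. Compound 4 retains a modest advantage over methyl, with a 2.5-fold lower number from compound 2 to compound 4 (0.40 log units; beyond the scatter), but shows no separation from benzyl, with a 1.2-fold higher number from compound 1 to compound 4 (0.08 log units; within the scatter), so among these compounds only compound 3 stands clear of benzyl. Nothing in the data shown gives a cause for this step.

The swap changes both the halogen and its ring position, and 4-chlorophenyl and 3-fluorophenyl would separate those two changes. Also open, going by these compounds, is how 3-methoxyphenyl, 3-carboxyphenyl or a longer alkyl chain on this nitrogen would compare.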